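A few compounds are considered here, and "the series" means these few. Any claim that something is new, unique, unknown or untested is made for them only; others in the source may bear on it.

In an ADME assay on MT4 cells (Homo sapiens) for cytotoxicity, read by MTT assay (a higher number here means that more compound is tolerated, a lower number that less compound is tolerated), three compounds sharing one core have been measured. Compound 1 `O=C(CSc1nncnc1-c1ccccc1Cl)c1ccc(Cl)c(Cl)c1` gives 33000 nM, compound 2 `O=C(CSc1nncnc1-c1ccccc1Cl)c1ccc(Br)cc1Br` gives 28000 nM, and compound 3 `O=C(CSc1nncnc1-c1ccccc1Cl)Nc1ccccc1F` gives 98000 nM, the highest number of the three. Compound 4 `O=C(CSc1nncnc1-c1ccccc1Cl)Nc1ccccc1[N+](=O)[O-]` has not yet been measured. It carries nitro in place of fluoro on an aromatic carbon, so 2-fluorophenyl becomes 2-nitrophenyl (nitro in place of fluoro on an aromatic carbon). Within the data shown here, no measured step makes this exchange. The nearest evidence comes from changes of the whole group on the carbonyl carbon: a 3.0-fold higher number from compound 1 to compound 3 (0.47 log units; beyond the scatter) and a 3.5-fold higher number from compound 2 to compound 3 (0.54 log units; beyond the scatter), both modest, while a 1.2-fold lower number from compound 1 to compound 2 (0.07 log units; within the scatter) stays within the scatter. Among the measured compounds shown here, these steps suggest only that changes at this end have so far moved the number modestly in this assay. No step beyond the scatter is therefore expected, with a slight lean towards a lower number, as compound 3 already stands highest. The expected step is a 1.4-fold lower number from compound 3 to compound 4 (0.15 log units; within the scatter). For compound 4 the estimated value is 70000 nM, with an expected range of 30000 nM to 120000 nM.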

Compound 4, half-maximal cytotoxic concentration: 63000 nM
Compound 4: the middle estimate sits 1.1-fold (0.05 log units) above what was measured; the range from low to high includes it.
By their numbers in this assay, from the lowest: compounds 2, 1, 4 and 3 (each within the scatter of the next, the first and the last beyond it).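

Among these compounds, compound 4 gives the first reading of a change made on the 2-fluorophenyl ring itself, since the earlier steps each exchanged the whole group on the carbonyl carbon. In this assay there is a 1.6-fold lower number from compound 3 to compound 4 (0.19 log units; within the scatter) for nitro in place of fluoro on an aromatic carbon. At this place, ortho to a large group, 3 heavy atoms with 2 hydrogen-bond acceptors thus stand where a single fluorine stood, with no step beyond the scatter, and nothing available here bears on the reason for this result.

The compounds shown leave open how an amine, a carboxylic acid or a methoxy group would read at this same place on the ring. They also leave open whether nitro or fluoro would give a similar number elsewhere on this ring, and what a change to the shared core would do.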